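The source may report more compounds than this note shows. Statements on the series, on what has been measured and on what is new or still open speak of the compounds shown alone.

Measured so far:
Compound 1, `CCN(C)C(=O)N1CCN(C(=S)SCc2cn(Cc3ccccc3F)nn2)CC1`, gives 5860 nM in a functional assay on MGC-803 cells (Homo sapiens) for cytotoxicity, read by MTT assay, with a stated time of 72 h; a higher number here means a weaker inhibitor, a lower number a stronger inhibitor.
Compound 2, `O=C(NC1CCCCC1)N1CCN(C(=S)SCc2cn(Cc3ccccc3F)nn2)CC1`, gives 36500 nM in this assay.
Compound 3, `CCN(C)C(=O)N1CCN(C(=S)SCc2cn(Cc3ccc(F)cc3)nn2)CC1`, gives 1550 nM in this assay.

All three share one core, and they differ from each other in two places. Compound 1 and compound 2 differ in the group on the carbonyl carbon: cyclohexylamino in place of ethyl(methyl)amino on a carbonyl carbon. That change brought a 6.2-fold higher number from compound 1 to compound 2 (0.79 log units; beyond the scatter). Compound 1 and compound 3 differ in the fluorophenyl ring hanging on the saturated chain carbon bound to an aromatic nitrogen: 4-fluorophenyl in place of 2-fluorophenyl on a saturated chain carbon bound to an aromatic nitrogen. That change brought a 3.8-fold lower number from compound 1 to compound 3 (0.58 log units; beyond the scatter), so compound 3 shows the lowest number of the three measured compounds, with compound 2 furthest from it.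

Compound 4, `O=C(NC1CCCCC1)N1CCN(C(=S)SCc2cn(Cc3ccc(F)cc3)nn2)CC1`, has not yet been measured in this assay. It stands to compound 3 exactly as compound 2 stands to compound 1: cyclohexylamino in place of ethyl(methyl)amino on a carbonyl carbon. The place is described in the same words for both pairs, so this is the same change, made a second time on the core that carries the 4-fluorophenyl ring. Among the measured compounds shown here, the only guide to its size is the single earlier step, a 6.2-fold higher number from compound 1 to compound 2 (0.79 log units; beyond the scatter), seen on the core that carries the 2-fluorophenyl ring. Taking that one step as the pattern, the expected step is a 6.2-fold higher number from compound 3 to compound 4 (0.79 log units; beyond the scatter), a weaker inhibitor than compound 3. For the measured compounds named here, with only one prior example, the range is kept wide. Compound 4 is therefore estimated at 9600 nM in this assay, with a likely span from 3500 nM to 26000 nM.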

Compound 4, half-maximal inhibitory concentration: > 128000 nM
Compound 4 was reported as a limit (the forecaster's own chance of this, stated with the estimate: 10%); at least 13-fold (1.12 log units) between middle value and limit.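

Compound 4 gives > 128000 nM in this assay, and that value is a limit of the assay, not a number. The cyclohexylamino swap, which brought an at least 82-fold higher number from compound 3 to compound 4 (1.91 log units; beyond the scatter), pushes the number the same way on both cores but not by the same amount, so its direction carried over from one core to the other while its size did not: the same change on two cores in this assay, a 6.2-fold higher number (0.79 log units; beyond the scatter) from compound 1 to compound 2 and an at least 82-fold higher number (1.91 log units; beyond the scatter) from compound 3 to compound 4, at least 13-fold (1.12 log units) apart, beyond the scatter of two such steps. The 4-fluorophenyl swap, which brought an at least 3.5-fold higher number from compound 2 to compound 4 (0.54 log units; beyond the scatter), goes the opposite way from its earlier step, so in these four compounds neither change can be carried to the other core unaltered, though the exact size of the gap stays unknown and the data do not show the reason for it: the same change on two cores in this assay, a 3.8-fold lower number (0.58 log units; beyond the scatter) from compound 1 to compound 3 and an at least 3.5-fold higher number (0.54 log units; beyond the scatter) from compound 2 to compound 4, at least 13-fold (1.12 log units) apart, beyond the scatter of two such steps.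

With only two pairs for each change, the compounds shown leave open whether this mismatch is particular to cyclohexylamino or would also appear with a smaller ring such as cyclopentylamino or an open chain such as butylamino. They also leave open how an unsubstituted phenyl ring in place of either fluorophenyl ring would behave on each of the two cores.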